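A Bromophenyl Ketone Arm on an Inactive Core

The source may report more compounds than this note shows. Statements on the series, on what has been measured and on what is new or still open speak of the compounds shown alone.

Three compounds share one core and differ only in the groups hung on it. Compound 1 `CCc1nnc(SC)n1N1C(=O)c2ccccc2C1=O` carries a methylsulfanyl group and a short chain, compound 2 `CCCc1nnc(SCC(=O)c2ccccc2)n1N1C(=O)c2ccccc2C1=O` a longer chain and a phenylcarbonylmethyl arm on the sulfur, and compound 3 `COc1cc(-c2nnc(SC)n2N2C(=O)c3ccccc3C2=O)cc(OC)c1OC` a methylsulfanyl group beside a trimethoxyphenyl ring. In a functional assay on HepG2 cells (Homo sapiens) for cytotoxicity, read by MTT assay, with a stated time of 48 h (on this read-out lower numbers stand for stronger inhibition and higher numbers for weaker inhibition), compound 1 gives > 200000 nM, which is a limit of the assay, not a number. In this assay compound 2 gives > 200000 nM, again a limit. Compound 3 gives > 200000 nM in this assay, once more a limit. Among the measured compounds shown here, every value so far sits at the limit of > 200000 nM in this assay, at which 3 of the 3 values shown sit, so compound 3 cannot be placed above or below its neighbours.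

Compound 4 `COc1cc(-c2nnc(SCC(=O)c3ccc(Br)cc3)n2N2C(=O)c3ccccc3C2=O)cc(OC)c1OC` keeps the core of compound 3 and changes one place: (4-bromophenyl)carbonyl in place of hydrogen on a saturated chain carbon bound to a sulfur. For the measured compounds named here, no step between two measured compounds is available for comparison. The expected step in this assay, a step that the limit leaves unreadable from compound 3 to compound 4, is no change beyond the scatter. Compound 4 is expected to give about 250000 nM, within 100000 nM to 600000 nM.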

Compound 4, half-maximal inhibitory concentration: 27700 nM
For compound 4 the middle estimate is 9.0-fold (0.96 log units) above the measured one; measured number below the stated range.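

In this assay, the saturated chain carbon bound to a sulfur proves to be a place where a change can move the read-out: (4-bromophenyl)carbonyl in place of hydrogen there gives an at least 7.2-fold lower number from compound 3 to compound 4 (0.85 log units; beyond the scatter). The earlier compounds shown here could not show this, as none of them gave a number that could be compared. Compound 4 is the only compound here with a measured number rather than a limit: the limit of > 200000 nM in this assay, at which 3 of the 4 values shown sit.

From the compounds shown here alone, it remains open which part of the new group matters, and whether chlorine or hydrogen in place of the bromine would give a similar number. Going by these compounds, it is equally open whether a longer chain, an amine or a carboxylic acid in place of the (4-bromophenyl)carbonyl would keep the number clear of the limit.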